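Imidazole to triazole in a fatty acid receptor agonist series

The compounds below may be only part of what the source reports. "The series", "measured", "known", "first", "only" and "open" are said of these compounds alone.

Compound 1 `CC#C[C@@H](CC(=O)O)c1ccc(OCc2cccc(-c3ccc(Cl)cc3C)c2)cc1` gives 36 nM in an assay on CHO cells for agonist activity at Free fatty acid receptor 1 (Homo sapiens), read by calcium flux; on this read-out higher numbers stand for an effect only at larger amounts of compound and lower numbers for an effect already at smaller amounts.
Compound 2 `Cc1cc(Cl)ccc1-c1cccc(COc2ccc([C@H](CC(=O)O)c3nccn3C)cc2)c1` gives 33 nM in this assay.

Of the two compounds measured, compound 2 has the lower number, but its step to compound 1 is within the scatter, so the two cannot be told apart. Compound 3 `Cc1cc(Cl)ccc1-c1cccc(COc2ccc([C@H](CC(=O)O)c3ncnn3C)cc2)c1` differs from compound 2 by 1-methyl-1H-1,2,4-triazol-5-yl in place of 1-methyl-1H-imidazol-2-yl on a saturated chain carbon bound to an aromatic carbon and a saturated chain carbon. For the measured compounds named here, no measured step bears directly on this exchange; the only measured step, a 1.1-fold lower number from compound 1 to compound 2 (0.04 log units; within the scatter), shows that a larger change at the same place left the number within the scatter. For compound 3 no step beyond the scatter is therefore expected, with a 1.2-fold higher number from compound 2 to compound 3 (0.08 log units; within the scatter) as the estimate. Compound 3 is expected to give 40 nM in this assay, with a range from 15 nM to 110 nM.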

Compound 3, half-maximal effective concentration: 33 nM
Compound 3: the middle estimate sits 1.2-fold (0.08 log units) above what was measured; measured number inside the range.
By their numbers in this assay, from the lowest: compounds 2, 3 and 1 (each within the scatter of the next).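

At this place, on a saturated chain carbon bound to an aromatic carbon and a saturated chain carbon, the ring tolerates a further nitrogen: 1-methyl-1H-1,2,4-triazol-5-yl in place of 1-methyl-1H-imidazol-2-yl gives no change at the digits printed from compound 2 to compound 3 (within the scatter) in this assay. Set against prop-1-yn-1-yl, the triazole reads as the imidazole did, with a 1.1-fold lower number from compound 1 to compound 3 (0.04 log units; within the scatter) in this assay, so these three groups cannot be told apart here. On these data alone, whether a 1-methyl-1H-tetrazol-5-yl group or an amine would hold the number as well stays open. Nothing at hand says why these groups read alike.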